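Amine side chain of compound 1: ether analogue

This account rests on a few compounds, and the source may have more. Where it says the series, first, only, none or still open, it means among the compounds named here.

Compound 1 `CCCCC(CC)Nc1nc(C)nc2c(-c3ccc(Cl)cc3Cl)c(C)nn12` carries a 1-ethylpentyl group on a ring nitrogen of the shared core. In an assay on isolated protein for displacement of a labelled ligand from corticotropin-releasing factor receptor 1 (Homo sapiens) (a lower number here means a stronger inhibitor, a higher number a weaker inhibitor), compound 1 gives 1.6 nM, level at the digits shown with compound 3 and together with it the highest of the three numbers; the nearest value is that of compound 3, the furthest that of compound 2. Compound 2 `CCN(CC)c1nc(C)nc2c(-c3ccc(Cl)cc3Cl)c(C)nn12` gives 1.2 nM, and compound 3 `CCCC(CCC)Nc1nc(C)nc2c(-c3ccc(Cl)cc3Cl)c(C)nn12` gives 1.6 nM.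

The step to compound 4 `CCOCC(COCC)Nc1nc(C)nc2c(-c3ccc(Cl)cc3Cl)c(C)nn12` is 2-ethoxy-1-(ethoxymethyl)ethyl in place of 1-ethylpentyl on a nitrogen on an aromatic ring. Going by the values given here, two measured steps touch the same position: no change at the digits printed from compound 1 to compound 3 (within the scatter) and a 1.3-fold lower number from compound 1 to compound 2 (0.12 log units; within the scatter); the third, a 1.3-fold higher number from compound 2 to compound 3 (0.12 log units; within the scatter), is likewise within the scatter. None of them brings in oxygen, so the ether chain of compound 4 reaches beyond what has been tested, and some extra uncertainty remains.

Compound 4 is expected to stay close, with a step of a 1.9-fold higher number from compound 1 to compound 4 (0.27 log units; within the scatter) leaning if anything towards a higher number, because no change at the digits printed from compound 1 to compound 3 (within the scatter) shows a change of chain shape on the same nitrogen without effect beyond the scatter. For compound 4 the estimate is 3 nM, with a range from 1 nM to 10 nM.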

Compound 4, inhibition constant: 6.2 nM
Compound 4: middle estimate off by 2.1-fold (0.32 log units), on the low side; low and high end bracket the measured number.
By their numbers in this assay, from the lowest: compounds 2, 1 and 3 (each within the scatter of the next); then compound 4.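

Working notes on the amine side chain: in this assay the ether chain gives the first change on this nitrogen that lies beyond the scatter (a 3.9-fold higher number from compound 1 to compound 4 (0.59 log units; beyond the scatter); a 3.9-fold higher number from compound 3 to compound 4 (0.59 log units; beyond the scatter)), both steps modest, whereas the steps among compounds 1, 2 and 3 all stayed within it. The group change is therefore not neutral at this position, even though 2-ethoxy-1-(ethoxymethyl)ethyl has the same 7 carbon as 1-ethylpentyl and differs in adding 2 oxygen, counted as 2 hydrogen-bond acceptors. No measurement available here accounts for the shift.

The compounds shown leave open whether the shift follows the number of ether oxygens, which a chain holding a single methoxy group could test. A tertiary amine such as bis(2-methoxyethyl)amino, or a hydroxyl-ended chain, would show whether the same holds beyond this one side chain.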